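Replacing a Pyrrolidine Carboxamide with a Dimethylacetamide Arm

A few compounds are considered here, and "the series" means these few. Any claim that something is new, unique, unknown or untested is made for them only; others in the source may bear on it.

Compound 1 `NC(=O)[C@@H]1CCCN1c1cc(=O)oc2cc(OCc3ccccc3)ccc12` is the weaker of the two measured compounds: in an assay (strain Wistar) for inhibition of Amine oxidase [flavin-containing] A (Rattus norvegicus) (on this read-out higher numbers stand for weaker inhibition and lower numbers for stronger inhibition), compound 1 gives 99800 nM, the highest number seen here. Its nearest neighbour, compound 2 `NC(=O)Cc1cc(=O)oc2cc(OCc3cccc(O)c3)ccc12`, gives 4270 nM in this assay, a lower number by a gap well beyond the scatter. Compound 3 `CN(C)C(=O)Cc1cc(=O)oc2cc(OCc3ccccc3)ccc12` has not been measured. It differs from compound 1 by (dimethylcarbamoyl)methyl in place of 2-carbamoylpyrrolidin-1-yl on an aromatic carbon. Compound 3 thus carries a short acetamide-type arm similar in kind to that of compound 2, though with a dimethylated amide and a plain benzyl ether rather than the hydroxylated one of compound 2. Given the lower number of compound 2 at 4270 nM, compound 3 is expected to show a clearly lower number than compound 1, a step of an 8.3-fold lower number from compound 1 to compound 3 (0.92 log units; beyond the scatter) in this assay. Compound 3 is estimated at 12000 nM, within the range 2500 nM to 60000 nM.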

Compound 3, half-maximal inhibitory concentration: 23100 nM
Compound 3: the middle estimate sits 1.9-fold (0.28 log units) below what was measured; the range from low to high includes it.
By their numbers in this assay, from the lowest: compound 2; then compound 3; then compound 1.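

On the aromatic carbon opposite the ring oxygen, with the rest of the core of compound 1 unchanged, placing (dimethylcarbamoyl)methyl in place of 2-carbamoylpyrrolidin-1-yl gives a 4.3-fold lower number from compound 1 to compound 3 (0.64 log units; beyond the scatter) in this assay. This is the first comparison shown that isolates this position, and it indicates that inhibition does not depend on keeping the five-membered ring, the defined stereocentre or the hydrogen-bond donor of the departing group, which all leave together in this modest step. Nothing shown accounts for the size or direction of this step.

Going by these compounds alone, the single swap does not show how much of the step belongs to removing the ring and how much to the dimethylated amide. An unsubstituted acetamide arm, a carboxylic acid or a longer chain at this position, on the same plain benzyl ether, would be needed to separate these contributions.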